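The compounds below may be only part of what the source reports. "The series", "measured", "known", "first", "only" and "open" are said of these compounds alone.

Series so far, tested in a functional assay on MDA-MB-231 cells (Homo sapiens) for antiproliferative activity, read by sulforhodamine B assay, with a stated time of 48 h (a higher number here means a weaker inhibitor, a lower number a stronger inhibitor), with these values
- compound 1 `COc1cc(OC)c2sc(-c3ccc(N/C=C\C(=O)c4ccc(OC)c([N+](=O)[O-])c4)c(C)c3)nc2c1` (10800 nM)
- compound 2 `COc1cc(OC)c2sc(-c3ccc(N/C=C\C(=O)c4cc(OC)c(OC)c(OC)c4Br)c(C)c3)nc2c1` (17300 nM)

Compound 2 gives 17300 nM and lies within the scatter of compound 1 (10800 nM), so these two values cannot be put in order. Compound 3 `COc1cc(OC)c2sc(-c3ccc(N/C=C\C(=O)c4cc(OC)c(OC)c(OC)c4)c(C)c3)nc2c1` has not yet been measured. It differs from compound 2 by a single exchange (hydrogen in place of bromo on an aromatic carbon), with hydrogen in place of bromo on an aromatic carbon.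

Within the data shown here, no measured pair isolates this exchange, so the data give no direct size for it. Among the measured compounds shown here, a small step toward a lower number is expected in this assay on weak grounds, since the only anchors are compound 1 at 10800 nM and compound 2 at 17300 nM in one narrow range. The estimated step runs a 1.9-fold lower number from compound 2 to compound 3 (0.28 log units; within the scatter) and is expected to stay about within the scatter. The range is kept wide because a single exchange on this evidence could go either way. For compound 3 the expected value is 9000 nM (estimated range 2500 nM to 30000 nM).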

Compound 3, half-maximal inhibitory concentration: 13800 nM
For compound 3 the middle estimate is 1.5-fold (0.19 log units) below the measured one, and the stated range covers the measured number.
By their numbers in this assay, from the lowest: compounds 1, 3 and 2 (each within the scatter of the next).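

In this assay, the exchange of hydrogen in place of bromo on an aromatic carbon, ortho to a large group, now has a direct reading: a 1.3-fold lower number from compound 2 to compound 3 (0.10 log units; within the scatter). At this position, therefore, bromo and hydrogen cannot be told apart in this read-out, and the exchange has no size that can be separated from repeat-measurement noise. The larger exchange of 3,4,5-trimethoxyphenyl in place of 4-methoxy-3-nitrophenyl on a carbonyl carbon gives a 1.3-fold higher number from compound 1 to compound 3 (0.11 log units; within the scatter), so replacing the whole group on the carbonyl carbon also gives no resolved difference, and no measurement here gives a reason for either result.

Among these compounds, how an amine or a carboxylic acid on the same aromatic carbon would read remains open, since hydrogen and bromo are the only two groups compared at that position. All three compounds sit in one narrow range of values, so the compounds shown do not indicate which change, on this ring or on the shared core, could move the number beyond the scatter.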